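Fluoro in Place of Trifluoromethyl on Compound 2

A few compounds are considered here, and "the series" means these few. Any claim that something is new, unique, unknown or untested is made for them only; others in the source may bear on it.

In a functional assay on HUVEC cells (Homo sapiens) for inhibition, with a stated time of 4 days (a lower number here means a stronger inhibitor, a higher number a weaker inhibitor), compound 1 (`COc1ccc(C(N)=O)cc1/C=C/c1ccc(Br)cc1`) gives 560 nM and compound 2 (`COc1ccc(C(N)=O)cc1/C=C/c1ccc(C(F)(F)F)cc1`) gives 880 nM. On these two numbers compound 2 stands level with compound 1, as the gap lies within the scatter. Compound 3 (`COc1ccc(C(N)=O)cc1/C=C/c1ccc(F)cc1`) keeps the shared core and carries fluoro in place of trifluoromethyl on an aromatic carbon, para to a large group: fluoro in place of trifluoromethyl on an aromatic carbon.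

Going by the values given here, one measured step bears on this change, with trifluoromethyl in place of bromo on that same aromatic carbon. That step, a 1.6-fold higher number from compound 1 to compound 2 (0.20 log units; within the scatter), stays small, so no step beyond the scatter is expected in this assay. Among the compounds with values here, no measured compound carries fluoro there, so the range is kept wide. The estimated step is a 1.2-fold lower number from compound 2 to compound 3 (0.07 log units; within the scatter). For compound 3 the expected value is 750 nM, with an estimated range from 280 nM to 2000 nM.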

Compound 3, half-maximal inhibitory concentration: 2100 nM
Estimate against measurement, compound 3: 2.8-fold (0.45 log units) below; the measured number lies above the stated range.
By their numbers in this assay, from the lowest: compounds 1 and 2 (each within the scatter of the next); then compound 3.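

Bromo and trifluoromethyl stood level at this aromatic carbon, but fluoro separates from both in this assay: replacing trifluoromethyl with fluoro gives a 2.4-fold higher number from compound 2 to compound 3 (0.38 log units; beyond the scatter), and replacing bromo with fluoro gives a 3.8-fold higher number from compound 1 to compound 3 (0.57 log units; beyond the scatter). This position, para to a large group, therefore does respond to a change of substituent, and compound 3, whose fluoro has 1 heavy atom against 4 for trifluoromethyl, is the weakest of the three, although three compounds set no general rule. The data shown offer no measurement that explains this rise in the number.

The compounds shown leave open whether chloro or methyl at this carbon would fall with bromo and trifluoromethyl or with fluoro. They also leave open how an amine or a carboxylic acid would behave at the same place on the shared core.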